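This account rests on a few compounds, and the source may have more. Where it says the series, first, only, none or still open, it means among the compounds named here.

Compound 1 `O=C(/C=C/c1ccc2c(C(F)(F)F)cccc2n1)c1ccccn1` gives 43100 nM in an ADME assay on A549 cells (Homo sapiens) for cytotoxicity; on this read-out higher numbers stand for weaker inhibition and lower numbers for stronger inhibition. Compound 2 `O=C(/C=C/c1ccc2c(C(F)(F)F)cccc2n1)c1cccnc1` reaches only a limit of this assay, > 50000 nM, so that the step of an at least 1.1-fold higher number from compound 1 to compound 2 (0.06 log units; that floor lies within the scatter) rests on the limit of > 50000 nM in this assay, at which 1 of the 3 values shown sits, and has no exact size. The change behind that step is pyridin-3-yl in place of pyridin-2-yl on a carbonyl carbon. Compound 3 `O=C(/C=C/c1ccc2ccc(C(F)(F)F)cc2n1)c1ccccn1` gives 10200 nM, the lowest number among the measured compounds, with compound 1 as the nearest measured value; how the core of compound 3 differs from the core of compound 1 is not broken down here.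

Compound 4 `O=C(/C=C/c1ccc2ccc(C(F)(F)F)cc2n1)c1cccnc1` has not yet been measured. Its difference from compound 3 is pyridin-3-yl in place of pyridin-2-yl on a carbonyl carbon, the same change that separates compound 1 from compound 2, made at the same place. The step of a 2.0-fold higher number from compound 3 to compound 4 (0.29 log units; within the scatter) is therefore expected to point the same way, with a size that stays uncertain, since the step from compound 1 to compound 2 is known only as a floor. Compound 4 is estimated at 20000 nM, within a band from 8000 nM to 50000 nM.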

Compound 4, half-maximal inhibitory concentration: 9800 nM
Estimate against measurement, compound 4: 2.0-fold (0.31 log units) above, within the range that was stated.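

In this assay, pyridin-3-yl in place of pyridin-2-yl on a carbonyl carbon gives no change beyond the scatter on the second core, a 1.0-fold lower number from compound 3 to compound 4 (0.02 log units; within the scatter). Set beside the step on the first core, the change reads as follows: the same change on two cores in this assay, an at least 1.1-fold higher number (0.06 log units; that floor lies within the scatter) from compound 1 to compound 2 and a 1.0-fold lower number (0.02 log units; within the scatter) from compound 3 to compound 4; the limit leaves it open whether they differ. The value of compound 2, > 50000 nM, is a limit and not a number, so these compounds do not show whether the change carries over from one core to the other with the same size or with a different one: the limit of > 50000 nM in this assay, at which 1 of the 4 values shown sits.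

The compounds shown carry only pyridin-2-yl and pyridin-3-yl on the carbonyl carbon, so it stays open how a pyridin-4-yl or a plain phenyl group there would read in this assay. On these data alone, it also stays open whether the same change would behave alike on a core carrying a nitrile or a methoxy group in place of the trifluoromethyl group.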